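From Carboxy to Carbamoyl on the Cyclohexyl Group

The source may report more compounds than this note shows. Statements on the series, on what has been measured and on what is new or still open speak of the compounds shown alone.

In an ADME assay on microsomes from liver (Mus musculus) for metabolic stability, with a stated time of 10 min (a higher number here means that more of the compound is left, a lower number that less of the compound is left), compound 3 (`C[C@]1(C(=O)N2CC[C@](c3ccc(C(F)(C(F)(F)F)C(F)(F)F)cc3)(S(=O)(=O)c3ccc(F)cc3)C2)CC[C@@H](C(=O)O)CC1`) shows 100% remaining and compound 1 (`C[C@]1(C(=O)O)CC[C@H](C(=O)N2CC[C@](c3ccc(C(F)(C(F)(F)F)C(F)(F)F)cc3)(S(=O)(=O)c3ccc(F)cc3)C2)CC1`) shows 93% remaining, so the two stand level. For compound 2 (`CC[C@]1(C(=O)O)CC[C@H](C(=O)N2CC[C@](c3ccc(C(F)(C(F)(F)F)C(F)(F)F)cc3)(S(=O)(=O)c3ccc(F)cc3)C2)CC1`) the result stands as "not determined" (no result reported) with no number to compare. Compound 4 (`NC(=O)[C@H]1CC[C@H](C(=O)N2CC[C@](c3ccc(C(F)(C(F)(F)F)C(F)(F)F)cc3)(S(=O)(=O)c3ccc(F)cc3)C2)CC1`) carries 4-carbamoylcyclohexyl in place of 4-carboxy-1-methylcyclohexyl on a carbonyl carbon. Among the measured compounds shown here, the one measured step shows a number 7 percentage points higher from compound 1 to compound 3 (within the scatter) and involves no carbamoyl group, so it offers only weak guidance. The expected step is a number 8 percentage points lower from compound 3 to compound 4 (within the scatter) in this assay and no change beyond the scatter is foreseen. For compound 4 the estimated value is 92% (expected range 78% to 100%).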

Compound 4, percent of the compound remaining: 100%
Compound 4: the middle estimate sits 8 percentage points below what was measured; measured number inside the range.
By their numbers in this assay, from the lowest: compounds 1, 3 and 4 (each within the scatter of the next).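

The earlier compounds shown here only moved a methyl group while keeping the carboxy group, whereas this change replaces the carboxy group with a carbamoyl group and also removes the methyl. In this assay, the result is no change at the digits printed from compound 3 to compound 4 (within the scatter) and a number 7 percentage points higher from compound 1 to compound 4 (within the scatter), so this position tolerates both changes made together, with no shift beyond the scatter. Nothing here explains why the numbers stay level.

As far as these compounds go, because both changes come together, the share of each remains unknown. From the compounds shown here alone, whether a cyclohexyl group carrying a nitrile or an amine would behave the same also remains open.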